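A few compounds are considered here, and "the series" means these few. Any claim that something is new, unique, unknown or untested is made for them only; others in the source may bear on it.

A small family of compounds shares one core and differs in the aromatic ring on the chain: compound 1 (`COc1ccc(C(=O)/C=C/c2cccc(F)c2)c2c1C=CC(C)(C)O2`), compound 2 (`COc1ccc(C(=O)/C=C/c2ccc(C(F)(F)F)cc2)c2c1C=CC(C)(C)O2`) and compound 3 (`COc1ccc(C(=O)/C=C/c2ccccc2Cl)c2c1C=CC(C)(C)O2`). In a functional assay on HT-29 cells (Homo sapiens) for antiproliferative activity, read by MTT assay, with a stated time of 24 h (on this read-out higher numbers stand for weaker inhibition and lower numbers for stronger inhibition), compound 1 gives > 10000 nM as a limit, not a number. Compound 2 gives > 10000 nM in the same way, again a limit. Compound 3 gives > 10000 nM as a limit too, so it has no exact number of its own and stands level with the other two only in that sense.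

The next compound is compound 4 (`COc1ccc(C(=O)/C=C/c2ccc(O)cc2)c2c1C=CC(C)(C)O2`). The change is 4-hydroxyphenyl in place of 2-chlorophenyl on a double-bonded chain carbon bound to a double-bonded chain carbon and it puts 4-hydroxyphenyl in place of 2-chlorophenyl on a double-bonded chain carbon bound to a double-bonded chain carbon. For the measured compounds named here, none of the measured compounds carries a hydroxyl group, so this is untested ground. What the data offer is the limit of > 10000 nM in this assay, at which 3 of the 3 values shown sit, and nothing finer. Because a step that the two limits leave unreadable from compound 1 to compound 3 offers no size to carry over, compound 4 is expected to stay close to compound 3, with no clear step in either direction. The expected step is a step that the limit leaves unreadable from compound 3 to compound 4 and this estimate is a loose one. For compound 4 the estimated value is 12000 nM with an expected range from 3000 nM to 30000 nM and a good chance of another limit.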

Compound 4, half-maximal inhibitory concentration: > 10000 nM
Compound 4: a limit, no number (the forecaster's own chance of this, stated with the estimate: 70%); the middle value lies beyond the limit too.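

In this assay, for the compounds shown here, compound 4 also gives only a limit, not a number, so no step to it from compound 1, compound 2 or compound 3 can be read: the limit of > 10000 nM in this assay, at which 4 of the 4 values shown sit. The compounds shown leave open whether any ring on the chain of the shared core would give an exact value in this assay, and how large the effect of each ring change is.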